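This account rests on a few compounds, and the source may have more. Where it says the series, first, only, none or still open, it means among the compounds named here.

In a functional assay on SK-OV-3 cells (Homo sapiens) for inhibition, read by sulforhodamine B assay, with a stated time of 48 h (a higher number here means a weaker inhibitor of growth, a lower number a stronger inhibitor of growth), three compounds built on the same core have been measured, and none of them has given a number. Compound 1 `COc1cc(-c2nn(-c3cccc(NC(=O)Nc4ccc(Cl)c(Cl)c4)c3)cc2-c2ccncc2)ccc1Cl` reads > 50000 nM, which is a limit of the assay. Compound 2 `COc1cc(-c2nn(-c3cccc(NC(=O)Nc4cccc(C(F)(F)F)c4)c3)cc2-c2ccncc2)ccc1Cl` reads > 50000 nM, also a limit. Compound 3 `COc1cc(-c2nn(-c3cccc(NC(=O)c4ccc(Cl)c(C(F)(F)F)c4)c3)cc2-c2ccncc2)ccc1Cl` reads > 32500 nM, again only a limit, and this is the starting point here. The spread of results is therefore (the limit of > 50000 nM in this assay, at which 2 of the 3 values shown sit), and (the limit of > 32500 nM in this assay, at which 1 of the 3 values shown sits).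

Compound 4 `COc1cc(-c2nn(-c3cccc(NC(=O)c4ccccc4)c3)cc2-c2ccncc2)ccc1Cl` differs from compound 3 in one place, with phenyl in place of 4-chloro-3-(trifluoromethyl)phenyl on a carbonyl carbon. The measured changes closest to this one also fall on that carbonyl carbon, namely a step that the two limits leave unreadable from compound 1 to compound 3 and a step that the two limits leave unreadable from compound 2 to compound 3. The neighbouring change on the amide-type nitrogen is a step that the two limits leave unreadable from compound 1 to compound 2. None of these has a readable size, so they give no direction and no magnitude to carry over. No step beyond the usual scatter can be argued for in this assay, and compound 4 is expected most likely to return a limit as well. For compound 4 the estimated value is 45000 nM, with an expected range of 20000 nM to 100000 nM. The estimate corresponds to an expected step that the limit leaves unreadable from compound 3 to compound 4.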

Compound 4, concentration for total growth inhibition: > 100000 nM
Compound 4: no number, only a limit; the forecaster's own chance of this, stated with the estimate: 80%; at least 2.2-fold (0.34 log units) between middle value and limit.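

In this assay compound 4 gives > 100000 nM, which is only a limit. Compound 1, compound 2 and compound 3 also stand only as limits, and no step among these four compounds can be read. The compounds shown leave open whether any group on that carbonyl carbon gives a measurable concentration for total growth inhibition in this assay.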